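Working notes: replacing phenyl in compound 1

The source may hold more compounds than are shown below. What is called first, only, known or untested is meant among the compounds shown, and "the series" means these compounds.

Compound 1 `O=C(C1CCN(c2ccccc2)CC1)N1N=CC[C@H]1c1ccccc1`: 6.3
Compound 2 `N#Cc1ccc(N2CCC(C(=O)N3N=CC[C@H]3c3cc(F)cc(F)c3)CC2)nn1`: 4.8

In a physicochemical assay for lipophilicity, read by HPLC, measured as chromatographic lipophilicity, at pH 7.4 (a higher number here means a more lipophilic compound, a lower number a more polar compound), compound 1 stands highest of the two numbers at 6.3 and compound 2 lies beyond the scatter below it. Compound 3 `O=C(c1cscn1)N1CCC(C(=O)N2N=CC[C@H]2c2ccccc2)CC1` carries (1,3-thiazol-4-yl)carbonyl in place of phenyl on an amine nitrogen in a ring. Among the compounds with values here, no measured pair isolates this change. A fall beyond the scatter is expected in this assay with a number 1.70 log units lower from compound 1 to compound 3 (beyond the scatter) as the estimated step. Compound 2 at 4.8 shows that numbers of this order occur in the series. Compound 3 is estimated at 4.6 (expected range 3.9 to 5.3).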

Compound 3, distribution coefficient: 3
The estimate for compound 3 lay 1.60 log units above the measured number, outside the stated range (below it).
By their numbers in this assay, from the lowest: compound 3; then compound 2; then compound 1.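

In this assay, within the data shown here, (1,3-thiazol-4-yl)carbonyl in place of phenyl on an amine nitrogen in a ring gives a number 3.30 log units lower from compound 1 to compound 3 (beyond the scatter), the only step that can be read in one place. It shows that the group on this amine nitrogen can move the number by a large amount with the rest of compound 1 unchanged. Nothing available bears on the reason for this fall.

The step changes the ring and adds a carbonyl together, so their shares remain unseparated. Benzoyl or 1,3-thiazol-4-yl on the same nitrogen would divide them.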